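Phenyl in Place of Cyclohexyl on Two Related Cores

The compounds below may be only part of what the source reports. "The series", "measured", "known", "first", "only" and "open" are said of these compounds alone.

Compound 1 `Cc1ccc(S(=O)(=O)N2CC[C@@H](Cl)C[C@@H]2C2CCCCC2)cc1` and compound 2 `Cc1ccc(S(=O)(=O)N2CC[C@@H](Cl)C[C@@H]2c2ccccc2)cc1` share one core, while compound 3 `Cc1ccc(S(=O)(=O)N2CCC(Br)=CC2C2CCCCC2)cc1` and compound 4 `Cc1ccc(S(=O)(=O)N2CCC(Br)=CC2c2ccccc2)cc1` share another; the difference between the two cores is not broken down here. In a functional assay on SW1573 cells (Homo sapiens) for antiproliferative activity, read by sulforhodamine B assay, with a stated time of 48 h (a higher number here means a weaker inhibitor of growth, a lower number a stronger inhibitor of growth), compound 1 gives 53000 nM. For compound 2 the assay reports only a limit, > 100000 nM. The change between them is phenyl in place of cyclohexyl on a saturated ring carbon, and it gave an at least 1.8-fold higher number from compound 1 to compound 2 (0.27 log units; that floor lies within the scatter), which rests on (the limit of > 100000 nM in this assay, at which 1 of the 3 values shown sits). Compound 3 gives 65000 nM in this assay. Compound 4 carries the same kind of change, (phenyl in place of cyclohexyl on a saturated ring carbon), though here the place lies two ring bonds from the ring atom that bears a bromo group rather than a chloro group. Compound 4 is expected to show a 1.7-fold higher number from compound 3 to compound 4 (0.23 log units; within the scatter) because the measured pair gave an at least 1.8-fold higher number from compound 1 to compound 2 (0.27 log units; that floor lies within the scatter), so the limit may be reached again. The estimate for compound 4 is 110000 nM, spanning 50000 nM to 300000 nM.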

Compound 4, concentration for 50% growth inhibition: 54000 nM
Compound 4: middle estimate off by 2.0-fold (0.31 log units), on the high side; low and high end bracket the measured number.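

On the core of compound 3, phenyl in place of cyclohexyl gave in this assay a 1.2-fold lower number from compound 3 to compound 4 (0.08 log units; within the scatter), so this pair cannot be told apart. Set beside the earlier pair, this gives no sign that the change has a clear effect on either core, yet it does not show that the two cores respond alike: the same change on two cores in this assay, an at least 1.8-fold higher number (0.27 log units; that floor lies within the scatter) from compound 1 to compound 2 and a 1.2-fold lower number (0.08 log units; within the scatter) from compound 3 to compound 4; the limit leaves it open whether they differ. Compound 2 is reported only as a limit, so the earlier step has a floor and no exact size: the limit of > 100000 nM in this assay, at which 1 of the 4 values shown sits.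

The compounds shown leave open whether another group on this saturated ring carbon, such as an amine or a carboxylic acid, would move the number beyond the scatter. They also do not break down the difference between the two cores.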